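The compounds below may be only part of what the source reports. "The series", "measured", "known", "first", "only" and "open" are said of these compounds alone.

Measured in an ADME assay on HEK293 cells (Homo sapiens) for cytotoxicity; a higher number here means a weaker inhibitor, a lower number a stronger inhibitor:
- Compound 1 `CC(C)(C)C(=O)N1C[C@H](NC(=O)c2ccc(-n3ccccc3=O)cc2)[C@H](NC(=O)c2ccc(Cl)s2)C1`: > 100000 nM
- Compound 2 `O=C(N[C@H]1CN(C(=O)C2CC2)C[C@H]1NC(=O)c1ccc(Cl)s1)c1ccc(-n2ccccc2=O)cc1`: > 100000 nM

Neither entry is a number. In this assay compound 2 gives > 100000 nM, which is a limit of the assay. Compound 1 gives > 100000 nM, also a limit. The record so far therefore comes down to the limit of > 100000 nM in this assay, at which 2 of the 2 values shown sit, and compound 2 cannot be placed more exactly than that.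

The next compound is compound 3 `COCC(=O)N1C[C@H](NC(=O)c2ccc(-n3ccccc3=O)cc2)[C@H](NC(=O)c2ccc(Cl)s2)C1`. It keeps the core of compound 2 and changes one group, methoxymethyl in place of cyclopropyl on a carbonyl carbon.

For the measured compounds named here, only one measured step bears on this change, as it falls at the same carbonyl carbon: a step that the two limits leave unreadable from compound 1 to compound 2. It has no readable size, so it offers no sign of how strongly this assay responds to changes at this place. No direction can be argued from it, and no change beyond the scatter is expected. The step expected is a number no higher from compound 2 to compound 3 (the limit leaves the size open). Compound 3 is most likely to be reported as a limit again. As a value, compound 3 is estimated at 100000 nM, with an expected range from 50000 nM to 200000 nM.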

Compound 3, half-maximal inhibitory concentration: > 100000 nM
Compound 3: no number, only a limit; the forecaster's own chance of this, stated with the estimate: 85%; the middle value sits exactly at the limit.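

For the compounds shown here, compound 3 gives > 100000 nM in this assay, which is again a limit of the assay, so no step among compound 1, compound 2 and compound 3 can be read. The record comes down to one limit: the limit of > 100000 nM in this assay, at which 3 of the 3 values shown sit.

What the compounds shown leave open is how any of these carbonyl substituents would compare on an actual number.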